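Moving the acetylpyrazole attachment point on a shared core

This account rests on a few compounds, and the source may have more. Where it says the series, first, only, none or still open, it means among the compounds named here.

Measured compounds:
compound 1, `CNC(=O)N1CCCc2ccc(NC(=O)c3cccc(-c4ccn(C(C)=O)n4)c3)cc21`: 87.6%
compound 2, `CNC(=O)N1CCCc2ccc(NC(=O)c3ccc(-c4cnn(C)c4)cc3)cc21`: 94.4%

The account follows two compounds that share one core and differ in the aryl group carried on the benzamide. In a functional assay on MV4-11 cells (Homo sapiens) for antiproliferative activity, with a stated time of 6 days, tested at 6.25 uM (on this read-out higher numbers stand for a stronger effect at the one concentration tested and lower numbers for a weaker effect), compound 1 gives 87.6%. In this assay compound 2 gives 94.4%, a number within the scatter of the value for compound 1, so the two compounds show the same effect at the single concentration tested. Compound 3, `CNC(=O)N1CCCc2ccc(NC(=O)c3cccc(-c4cnn(C(C)=O)c4)c3)cc21`, is not yet measured. It differs from compound 1 by 1-acetyl-1H-pyrazol-4-yl in place of 1-acetyl-1H-pyrazol-3-yl on an aromatic carbon, on an aromatic carbon of a six-membered aromatic ring of carbon only, meta to a large group. For the measured compounds named here, no step between measured compounds is available to guide the expectation, so the step of a number 0.4 percentage points higher from compound 1 to compound 3 (within the scatter) is expected to lie within the scatter, in no particular direction. Compound 3 is therefore estimated at 88%, with a range from 74% to 97%.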

Compound 3, a percentage reported as inhibition, at one concentration (the size of the read-out at that concentration, not a potency): 82%
For compound 3 the middle estimate is 6 percentage points above the measured one, and the stated range covers the measured number.
By their numbers in this assay, from the lowest: compounds 3, 1 and 2 (each within the scatter of the next, the first and the last beyond it).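

Exchanging 1-acetyl-1H-pyrazol-3-yl for 1-acetyl-1H-pyrazol-4-yl at this place, on the six-membered aromatic ring of carbon only and meta to a large group, gives in this assay a number 5.6 percentage points lower from compound 1 to compound 3 (within the scatter). For the compounds shown here, this is the only step here between compounds that differ in one place, and it shows that, at the single concentration tested, the effect of the two attachment points cannot be told apart. No measurement is available that bears on this result.

Going by these compounds, it remains open whether the two compounds would also match at other concentrations, since a read-out at one concentration is not a potency. On these data alone, it also remains open how this place would tolerate a different group on the pyrazole in place of the acetyl, such as a primary amine or a carboxylic acid.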